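This account rests on a few compounds, and the source may have more. Where it says the series, first, only, none or still open, it means among the compounds named here.

Working notes on a series built on one shared core. In an ADME assay on MT4 cells (Homo sapiens) for cytotoxicity, read by MTT assay (on this read-out lower numbers stand for higher toxicity in this test and higher numbers for lower toxicity in this test), compound 1 `Cc1cc(C)cc(S(=O)(=O)c2c(C(=O)NCC(=O)NC(C)c3ccccc3)[nH]c3ccc(Cl)cc23)c1` gives 29400 nM. Compound 2 `Cc1cc(C)cc(S(=O)(=O)c2c(C(=O)NC(C)C(=O)NCCn3c(C)cnc3[N+](=O)[O-])[nH]c3ccc(Cl)cc23)c1` gives 16000 nM in this assay. For compound 3 `Cc1cc(C)cc(S(=O)(=O)c2c(C(=O)NCc3cccc(F)c3F)[nH]c3ccc(Cl)cc23)c1` this assay reports only a limit, > 51100 nM. Compound 3 thus stands at the edge of the numbers shown, without a number of its own. Among the measured compounds shown here, the one measured step bearing on the present change is an at least 1.7-fold higher number from compound 1 to compound 3 (0.24 log units; that floor lies within the scatter), and its floor comes from the limit of > 51100 nM in this assay, at which 1 of the 3 values shown sits. Compound 4 `Cc1cc(C)cc(S(=O)(=O)c2c(C(=O)NC(C)C(=O)NCc3ccco3)[nH]c3ccc(Cl)cc23)c1` differs from compound 3 by 1-(((furan-2-yl)methyl)carbamoyl)ethyl in place of 2,3-difluorobenzyl on an amide-type nitrogen. This restores the chain type seen in compound 1 and compound 2, so compound 4 is expected to land near those two, meaning a downward step an at least 2.0-fold lower number from compound 3 to compound 4 (0.31 log units; beyond the scatter) from the limit. The estimate for compound 4 is 25000 nM, with a range from 10000 nM to 60000 nM.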

Compound 4, half-maximal cytotoxic concentration: 24200 nM
Compound 4: middle estimate off by 1.0-fold (0.01 log units), on the high side; the range from low to high includes it.
By their numbers in this assay, from the lowest: compounds 2, 4 and 1 (each within the scatter of the next). At a limit, above all of these: compound 3.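

On an amide-type nitrogen, 1-(((furan-2-yl)methyl)carbamoyl)ethyl in place of 2,3-difluorobenzyl gives an at least 2.1-fold lower number from compound 3 to compound 4 (0.32 log units; beyond the scatter) in this assay and is the only step shown here beyond the scatter. By contrast, a 1.5-fold higher number from compound 2 to compound 4 (0.18 log units; within the scatter) and a 1.2-fold lower number from compound 1 to compound 4 (0.08 log units; within the scatter) both stay within the scatter, so these three chain-bearing compounds are not separated in this test. On these data alone, whether an amine or a carboxylic acid on the same chain would fall with them remains open. Compound 3 is given only as a limit, and the full size of its step stays open: the limit of > 51100 nM in this assay, at which 1 of the 4 values shown sits.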